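Swapping 3,4-difluorophenyl for 2,5-difluorophenyl in compound 3

The source may hold more compounds than are shown below. What is called first, only, known or untested is meant among the compounds shown, and "the series" means these compounds.

In an ADME assay on LLC-MK2 cells (Macaca mulatta) for cytotoxicity, read by spectrophotometry and crystal violet staining, with a stated time of 4 days (a higher number here means that more compound is tolerated, a lower number that less compound is tolerated), compound 1 `CC(C)n1ncc2c(C(=O)Nc3ncccn3)cc(-c3cccs3)nc21` gives 75000 nM and compound 2 `CC(C)n1ncc2c(C(=O)N3CCc4cccnc43)cc(-c3cccs3)nc21` gives 50000 nM as its reading. Between them lies a 1.5-fold lower number from compound 1 to compound 2 (0.18 log units; within the scatter) and no more. Compound 3 `CC(C)n1ncc2c(C(=O)Nc3ccc(F)c(F)c3)cc(-c3cccs3)nc21` reports > 200000 nM as a limit of the assay and not as a number. Two steps reach that limit: an at least 2.6-fold higher number from compound 1 to compound 3 (0.42 log units; beyond the scatter) and also an at least 4.0-fold higher number from compound 2 to compound 3 (0.60 log units; beyond the scatter) in the same test. Compound 4 `CC(C)n1ncc2c(C(=O)Nc3cc(F)ccc3F)cc(-c3cccs3)nc21` follows from compound 3 through 2,5-difluorophenyl in place of 3,4-difluorophenyl on an amide-type nitrogen with the same atoms joined differently. Both measured steps exchanged the whole group on the carbonyl side, and neither moved a fluorine around the ring, so they bear on this change only indirectly. The difluorophenyl ring stays, and compound 3 gained it in an at least 2.6-fold higher number from compound 1 to compound 3 (0.42 log units; beyond the scatter) on this same nitrogen, so no step beyond the scatter is expected in this assay here. The expected change is a number no higher from compound 3 to compound 4 (the limit leaves the size open) and no direction is favoured. For compound 4 the estimate is 200000 nM within an expected range of 90000 nM to 400000 nM and the reading may again prove to be a limit.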

Compound 4, half-maximal cytotoxic concentration: 100000 nM
The estimate for compound 4 lay 2.0-fold (0.30 log units) above the measured number, within the range that was stated.
By their numbers in this assay, from the lowest: compounds 2, 1 and 4 (each within the scatter of the next). At a limit, above all of these: compound 3.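

In this assay, this is the only step shown that moves the fluorines around the ring while keeping the same atoms, and it reads as an at least 2.0-fold lower number from compound 3 to compound 4 (0.30 log units; that floor lies within the scatter), so its floor alone does not separate the two arrangements. Compound 3 stands at a limit of the assay, which leaves the true size of this step open: the limit of > 200000 nM in this assay, at which 1 of the 4 values shown sits. The clear separation that 3,4-difluorophenyl showed from the other two amides does not appear with 2,5-difluorophenyl, which reads as a 1.3-fold higher number from compound 1 to compound 4 (0.12 log units; within the scatter) and as a 2.0-fold higher number from compound 2 to compound 4 (0.30 log units; within the scatter).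

The compounds shown leave open how a phenyl ring carrying a single fluorine, a chlorine or a methoxy group would read on this nitrogen. They also leave open whether other difluorophenyl arrangements would fall at a limit or among the measured numbers.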